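Two Inactive Sulfonyl Hydrazides and a Dichlorophenyl Analogue

The compounds below may be only part of what the source reports. "The series", "measured", "known", "first", "only" and "open" are said of these compounds alone.

Measured compounds:
compound 1, `CC(=O)Nc1ccc(S(=O)(=O)NNC(=O)c2cccnc2Nc2ccc(Cl)cc2)cc1`: > 100000 nM
compound 2, `O=C(NNS(=O)(=O)c1ccc(F)cc1)c1cccnc1Nc1ccc(Cl)cc1Cl`: > 100000 nM

Both compounds share a core carrying an aryl sulfonyl hydrazide and an anilino group, and both were tested in a functional assay on SW-620 cells (Homo sapiens) for antiproliferative activity; a lower number here means that less compound is tolerated, a higher number that more compound is tolerated. For compound 1 the value of > 100000 nM is a limit of the assay, not a number. For compound 2 the value of > 100000 nM is likewise a limit. Compound 1 therefore stands nowhere in particular on the numbers shown: the limit of > 100000 nM in this assay, at which 2 of the 2 values shown sit, so no ordering of the two compounds is possible and nothing can be said about how the difference between them acts.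

Compound 3, `O=C(NNS(=O)(=O)c1ccc(Cl)cc1Cl)c1cccnc1Nc1ccc(Cl)cc1`, has not yet been measured. It differs from compound 1 at one place: 2,4-dichlorophenyl in place of 4-acetamidophenyl on a sulfonyl sulfur. For the measured compounds named here, no step between measured compounds covers this change. Given that compound 1 sits at the limit (the limit of > 100000 nM in this assay, at which 2 of the 2 values shown sit), the expected change is a number no higher from compound 1 to compound 3 (the limit leaves the size open), none beyond the scatter. Compound 3 is expected to give 100000 nM, with a range from 30000 nM to 300000 nM, most probably reported again as a limit rather than a number.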

Compound 3, concentration lethal to 50% of the cells: > 100000 nM
Compound 3 was reported as a limit; the forecaster's own chance of this, stated with the estimate: 75%; the middle value sits exactly at the limit.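

No step can be read from compound 1 to compound 3, and compounds 1, 2 and 3 all stand at the same limit of the assay, not at numbers: the limit of > 100000 nM in this assay, at which 3 of the 3 values shown sit. The compounds shown leave open whether any group on the sulfonyl sulfur gives a measurable value in this assay, and how large its effect would be.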